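The source may report more compounds than this note shows. Statements on the series, on what has been measured and on what is new or still open speak of the compounds shown alone.

Measured compounds:
Compound 1 `COc1ccc(CNC(=O)/C=C/c2coc3cc(O)ccc3c2=O)cc1` gives 8430 nM in a functional assay on Huh-7 cells (Homo sapiens) for inhibition, read by MTT assay, with a stated time of 48 h; a higher number here means a weaker inhibitor, a lower number a stronger inhibitor.
Compound 2 `COc1ccc2c(=O)c(/C=C/C(=O)NCc3ccc(F)cc3)coc2c1` gives 21000 nM in this assay.
Compound 3 `O=C(/C=C/c1coc2cc(O)ccc2c1=O)NCc1ccc(F)cc1` gives only a limit in this assay: > 100000 nM.

Among the three, compound 3 stands at the limit of what this assay reports (the limit of > 100000 nM in this assay, at which 1 of the 3 values shown sits), so its true number is not known. Compound 4 `COc1ccc(NC(=O)/C=C/c2coc3cc(O)ccc3c2=O)cc1` differs from compound 3 by 4-methoxyphenyl in place of 4-fluorobenzyl on an amide-type nitrogen. Among the measured compounds shown here, one measured step bears on this change: an at least 11-fold higher number from compound 1 to compound 3 (1.07 log units; beyond the scatter), where a fluoro replaced a methoxy on the aromatic ring that hangs from the amide nitrogen. Going from compound 3 to compound 4 returns the methoxy, so a lower number is expected. The other step, an at least 4.7-fold higher number from compound 2 to compound 3 (0.67 log units; beyond the scatter), concerns the oxygen on the shared core and does not touch the changed part. For the measured compounds named here, the loss of the methylene between the amide nitrogen and the ring has no measured counterpart here, so the size of the step is uncertain. Compound 4 is expected to give about 15000 nM, within a range from 4000 nM to 100000 nM. The expected step is an at least 6.6-fold lower number from compound 3 to compound 4 (0.82 log units; beyond the scatter).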

Compound 4, half-maximal inhibitory concentration: > 100000 nM
Compound 4: no number, only a limit; the forecaster's own chance of this, stated with the estimate: 25%; middle value at least 6.6-fold (0.82 log units) away from the limit.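

Compound 3 and compound 4 both give only a limit in this assay, so no step between them can be read: the limit of > 100000 nM in this assay, at which 2 of the 4 values shown sit.

The compounds shown leave open how far 4-methoxyphenyl in place of 4-fluorobenzyl on the amide-type nitrogen truly shifts the number in this assay.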